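This account rests on a few compounds, and the source may have more. Where it says the series, first, only, none or still open, it means among the compounds named here.

Measured so far:
compound 1, `CC(=O)N1N=C(c2ccco2)CC1c1ccccc1[N+](=O)[O-]`: 19000 nM
compound 2, `CC(=O)N1N=C(c2ccco2)CC1c1cccc([N+](=O)[O-])c1`: 20000 nM

In a functional assay on PC-3 cells (Homo sapiens) for cytotoxicity, read by sulforhodamine B assay, with a stated time of 48 h (on this read-out higher numbers stand for weaker inhibition and lower numbers for stronger inhibition), compound 1 gives 19000 nM and compound 2 gives 20000 nM; the two values lie within the scatter of each other, so neither is told apart from the other on this read-out. Compound 3, `CC(=O)N1N=C(c2ccco2)CC1c1cccc(O)c1`, is not yet measured. It differs from compound 2 by hydroxy in place of nitro on an aromatic carbon. Among the compounds with values here, no measured step of this kind is available, so the size and direction of no change at the digits printed from compound 2 to compound 3 (within the scatter) are expected to stay within the scatter. For compound 3 the estimate in this assay is 20000 nM, with a range from 8000 nM to 50000 nM.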

Compound 3, half-maximal inhibitory concentration: 16500 nM
Compound 3: middle estimate off by 1.2-fold (0.08 log units), on the high side; low and high end bracket the measured number.
By their numbers in this assay, from the lowest: compounds 3, 1 and 2 (each within the scatter of the next).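

In this assay, hydroxy in place of nitro on this aromatic carbon, meta to a large group, gives a 1.2-fold lower number from compound 2 to compound 3 (0.08 log units; within the scatter), so the number is not told apart even though a hydrogen-bond donor enters and the double bond outside aromatic rings leaves. Within the data shown here, this is the first step at this place, and it shows no dependence on which of these two groups sits there. No measurement available here accounts for this result. Going by these compounds, whether an amine or a carboxylic acid on the same carbon would move the number beyond the scatter remains open.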